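Methoxy for Trifluoromethyl on a Second Core

The source may report more compounds than this note shows. Statements on the series, on what has been measured and on what is new or still open speak of the compounds shown alone.

Compound 1 `O=C1C=COC(/C=C/c2ccc(C(F)(F)F)cc2)C1`: 33.3 uM
Compound 2 `COc1ccc(/C=C/C2CC(=O)C=CO2)cc1`: 204 uM
Compound 3 `O=C1C=CCC(/C=C/c2ccc(C(F)(F)F)cc2)N1`: 139 uM

All three were tested in a functional assay on HT-29 cells (Homo sapiens) for inhibition, read by sulforhodamine B assay, with a stated time of 48 h; a higher number here means a weaker inhibitor of growth, a lower number a stronger inhibitor of growth. Compound 1 and compound 2 share one core and differ in a single place: methoxy in place of trifluoromethyl on an aromatic carbon. That change made a step of a 6.1-fold higher number from compound 1 to compound 2 (0.79 log units; beyond the scatter). Compound 3 carries the same trifluoromethyl group on a different core; how the two cores differ is not broken down here. Compound 3 sits close to compound 2 in this assay, within the scatter, and well above compound 1.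

Compound 4 `COc1ccc(/C=C/C2CC=CC(=O)N2)cc1` has not yet been measured. It stands to compound 3 exactly as compound 2 stands to compound 1, the same change at the same place: methoxy in place of trifluoromethyl on an aromatic carbon. For the measured compounds named here, the step expected in this assay is a 3.6-fold higher number from compound 3 to compound 4 (0.56 log units; beyond the scatter), because the only earlier instance of this change gave a 6.1-fold higher number from compound 1 to compound 2 (0.79 log units; beyond the scatter). With a single precedent on a different core, the range is kept wide, and a value so weak may be returned only as a limit. Compound 4 is expected to give about 500 uM, between 180 uM and 1500 uM.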

Compound 4, concentration for growth inhibition (reported as GI): > 1090 uM
Compound 4 gave a limit, no number; the forecaster's own chance of this, stated with the estimate: 30%; at least 2.1-fold (0.33 log units) between middle value and limit.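

On both cores, methoxy in place of trifluoromethyl weakened growth inhibition in this assay, and on the second core the change gave an at least 7.8-fold higher number from compound 3 to compound 4 (0.89 log units; beyond the scatter), so the direction carried over from one core to the other: the same change on two cores in this assay, a 6.1-fold higher number (0.79 log units; beyond the scatter) from compound 1 to compound 2 and an at least 7.8-fold higher number (0.89 log units; beyond the scatter) from compound 3 to compound 4; the limit leaves it open whether they differ

Compound 4 reads > 1090 uM, which is a limit of the assay and not a number.

For the compounds shown here, the size of the step on the second core therefore has only a lower bound, and these compounds cannot show whether the change costs the same on both cores or more on one of them; with only two cores, they also establish no general rule for this series.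

On these data alone, only trifluoromethyl and methoxy stand at this place on the aromatic ring, so it remains open how a chlorine, an amine or a carboxylic acid there would behave on either core. As far as these compounds go, it also remains open how the same change would read on a third core.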